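Swapping a Hydroxyphenyl for a Phenethyl Group

The source may hold more compounds than are shown below. What is called first, only, known or untested is meant among the compounds shown, and "the series" means these compounds.

Compound 1: `CCCCCCCCS(=O)(=O)Nc1cc(-c2ccccc2Cl)ccc1C(=O)O` — 26900 nM
Compound 2: `CCCCCCCCS(=O)(=O)Nc1cc(-c2ccccc2O)ccc1C(=O)O` — 63100 nM
Compound 3: `CCCCCCCCS(=O)(=O)Nc1cc(CCc2ccccc2)ccc1C(=O)O` — not yet measured

Of the compounds shown here, two have been measured in an assay on mitochondria (strain BALB/c) for inhibition of glycerol-3-phosphate acyltransferase 1, mitochondrial (Mus musculus), read by scintillation counting, with a stated time of 10 min; a higher number here means a weaker inhibitor, a lower number a stronger inhibitor. Compound 1 `CCCCCCCCS(=O)(=O)Nc1cc(-c2ccccc2Cl)ccc1C(=O)O` gives 26900 nM. Among the compounds with values here, compound 2 `CCCCCCCCS(=O)(=O)Nc1cc(-c2ccccc2O)ccc1C(=O)O` gives 63100 nM, which is the higher of the two numbers; the only recorded step, a 2.3-fold higher number from compound 1 to compound 2 (0.37 log units; beyond the scatter), is a modest change from a hydroxy in place of a chloro on an aromatic carbon.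

Compound 3 `CCCCCCCCS(=O)(=O)Nc1cc(CCc2ccccc2)ccc1C(=O)O` has not yet been measured in this assay. The change from compound 2 to compound 3 is phenethyl in place of 2-hydroxyphenyl on an aromatic carbon. Within the data shown here, the single measured step bears on it only loosely: it shows that the group at this position matters, but it compares two substituted phenyl rings, whereas compound 3 carries a phenethyl chain with no donor or acceptor. The ring alone was not measured, so the direction of the change cannot be read off. The expectation is therefore a step of a 2.0-fold lower number from compound 2 to compound 3 (0.29 log units; within the scatter), with wide uncertainty. Compound 3 is estimated at 32000 nM, within a range of 10000 nM to 100000 nM.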

Compound 3, half-maximal inhibitory concentration: 37500 nM
Beside the measured number, compound 3's estimate is 1.2-fold (0.07 log units) below it; measured number inside the range.
By their numbers in this assay, from the lowest: compounds 1, 3 and 2 (each within the scatter of the next, the first and the last beyond it).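

In this assay, replacing 2-hydroxyphenyl with phenethyl gives a 1.7-fold lower number from compound 2 to compound 3 (0.23 log units; within the scatter) and replacing 2-chlorophenyl with phenethyl gives a 1.4-fold higher number from compound 1 to compound 3 (0.14 log units; within the scatter), so compound 3 cannot be told apart from either of the other two, even though compound 1 and compound 2 do differ from each other beyond the scatter. This position therefore accepts a phenethyl group, with no hydrogen-bond donor or acceptor and a chain linking its ring to the core, without any change that can be read beyond the scatter, and the hydrogen-bond donor and acceptor of the 2-hydroxyphenyl group are not required to reach this level of inhibition. Nothing available explains how these three numbers relate to the groups that carry them.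

The compounds shown leave open how a plain phenyl ring or a benzyl group would compare at this position, which would help separate the contribution of the ring substituent from that of the chain. As far as these compounds go, it also remains open whether adding a chloro or hydroxy group to the phenethyl ring, or placing an amine or a carboxylic acid on it, would move the number beyond the scatter.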